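Aryl ether to aryl thioether on the shared diamino core

The source may report more compounds than this note shows. Statements on the series, on what has been measured and on what is new or still open speak of the compounds shown alone.

Compound 1 `Nc1cc(N)c2nc(-c3ccccc3)c(Oc3ccc(Cl)c(Cl)c3)nc2c1` bears a 3,4-dichlorophenoxy group on an aromatic carbon of the shared core. In a functional assay on Hs-578T cells (Homo sapiens) for inhibition, read by sulforhodamine B assay, with a stated time of 48 h (on this read-out higher numbers stand for weaker inhibition of growth and lower numbers for stronger inhibition of growth), compound 1 gives 33900 nM. Compound 2 `Nc1cc(N)c2nc(-c3ccccc3)c(NCc3ccc(Cl)c(Cl)c3)nc2c1`, which keeps the core and the phenyl group, gives 46800 nM in this assay; the two numbers lie within the usual scatter of each other, so no order between compound 1 and compound 2 can be read from them. Compound 3 `CCOC(=O)[C@H](CCC(=O)O)NC(=O)c1ccc(Oc2nc3cc(N)cc(N)c3nc2-c2ccccc2)cc1` is reported in this assay only as a limit of the assay, < 100000 nM, and not as a number. That is the one case here of the limit of < 100000 nM in this assay, at which 1 of the 3 values shown sits.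

Compound 4 `COc1ccc(Sc2nc3cc(N)cc(N)c3nc2-c2ccccc2)cc1` is the next compound; it differs from compound 1 by (4-methoxyphenyl)sulfanyl in place of 3,4-dichlorophenoxy on an aromatic carbon. Among the measured compounds shown here, no pair of measured compounds shows this change, so there is no measured step to lean on, and the only anchor is the value of compound 1. The step from the ether of compound 1 to the thioether of compound 4 is therefore expected to be a 1.1-fold lower number from compound 1 to compound 4 (0.03 log units; within the scatter), that is, none beyond the scatter in either direction. On that basis compound 4 is estimated at 32000 nM in this assay, with a range from 10000 nM to 95000 nM.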

Compound 4, concentration for total growth inhibition: < 100000 nM
Compound 4: a limit, no number (the forecaster's own chance of this, stated with the estimate: 20%); the middle value lies beyond the limit too.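

In this assay, among the compounds shown here, compound 4 gives < 100000 nM, a limit of the assay and not a number, so no step between compound 1 and compound 4 can be read. Compound 4 joins compound 3 at this limit: the limit of < 100000 nM in this assay, at which 2 of the 4 values shown sit.

The compounds shown leave open whether (4-methoxyphenyl)sulfanyl in place of 3,4-dichlorophenoxy on an aromatic carbon changes growth inhibition at all.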